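A few compounds are considered here, and "the series" means these few. Any claim that something is new, unique, unknown or untested is made for them only; others in the source may bear on it.

Measured so far in an assay for inhibition of Fatty-acid amide hydrolase 1 (Rattus norvegicus); on this read-out lower numbers stand for stronger inhibition and higher numbers for weaker inhibition:

Compound 1, `COC(=O)c1ccc(C#CCCCCC(=O)c2ncc(-c3ccccn3)o2)cc1`, gives 25 nM.
Compound 2, `O=C(CCCCC#Cc1ccccn1)c1ncc(-c2ccccn2)o1`, gives 280 nM.
Compound 3, `O=C(CCCCC#Cc1ccc(Cl)cc1)c1ncc(-c2ccccn2)o1`, gives 20 nM.

Compound 3 holds the lowest of the three numbers, but not by a margin that means much against compound 1: the step of a 1.3-fold lower number from compound 1 to compound 3 (0.10 log units; within the scatter) lies within the usual scatter of this assay. Against compound 2 the gap is real, a 14-fold lower number from compound 2 to compound 3 (1.15 log units; beyond the scatter).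

Compound 4, `CC(C)(C)OC(=O)Nc1ccc(C#CCCCCC(=O)c2ncc(-c3ccccn3)o2)cc1`, keeps everything of compound 3 except one group on the aromatic ring: (tert-butoxycarbonyl)amino in place of chloro on an aromatic carbon.

Within the data shown here, of the two measured steps, only the one from compound 1 to compound 3 bears directly on this change, since it also swaps the group on that same aromatic carbon while the rest of the molecule stays fixed, and that swap moved the number only within the scatter. The step from compound 2 to compound 3 exchanges the whole ring at the triple bond and so tells little here. The incoming group is larger than either of the two already tried, so a mild rise is possible, but no step beyond the scatter is expected: a 1.5-fold higher number from compound 3 to compound 4 (0.18 log units; within the scatter). The estimate for compound 4 is therefore 30 nM, within a range of 10 nM to 90 nM.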

Compound 4, inhibition constant: 23 nM
For compound 4 the middle estimate is 1.3-fold (0.12 log units) above the measured one; the range from low to high includes it.
By their numbers in this assay, from the lowest: compounds 3, 4 and 1 (each within the scatter of the next); then compound 2.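

In this assay, the aromatic carbon para to a large group accepts a much larger substituent with no clear effect: (tert-butoxycarbonyl)amino brings 8 heavy atoms and 1 hydrogen-bond donor in place of the single chlorine atom of chloro, yet the result is a 1.2-fold higher number from compound 3 to compound 4 (0.06 log units; within the scatter) and no more. The comparison with the ester tells the same story, with a 1.1-fold lower number from compound 1 to compound 4 (0.04 log units; within the scatter) when (tert-butoxycarbonyl)amino takes the place of methoxycarbonyl, so the three groups tried on this carbon of the benzene-type ring cannot be told apart in this assay. No available evidence bears on why the number holds steady across such different groups.

The compounds shown leave open whether this tolerance extends to a free amine or a carboxylic acid on the same carbon, either of which could behave differently from the three neutral groups seen so far. On these data alone, it also remains open whether a longer chain between the triple bond and the ketone carbonyl would keep the numbers of compound 3 and compound 4 within reach.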